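Swapping an ethyl for a fluorophenyl on the isoxazole arm

The source may report more compounds than this note shows. Statements on the series, on what has been measured and on what is new or still open speak of the compounds shown alone.

Of the compounds shown here, three sharing one core have been measured in an assay on BaF3 cells for inhibition of proto-oncogene tyrosine-protein kinase receptor Ret (Homo sapiens), read by MTT assay, with a stated time of 48 h; on this read-out higher numbers stand for weaker inhibition of growth and lower numbers for stronger inhibition of growth. Compound 1 `Nc1ncnc2c1c(-c1cc(C3CC3)on1)nn2C1CCCCC1` gives 520 nM, and compound 3 `Nc1ncnc2c1c(-c1cc(C3CC3)on1)nn2C1CCOCC1` gives 440 nM. Going by the values given here, the one step between them, a 1.2-fold lower number from compound 1 to compound 3 (0.07 log units; within the scatter), shows that exchanging those two saturated rings on the aromatic nitrogen hardly moves the number. Compound 2 `CCc1cc(-c2nn(C(C)C)c3ncnc(N)c23)no1` gives 1560 nM and stands as the highest of the three numbers, so it is the weakest inhibitor of growth here, its gap to compound 1 and to compound 3 lying beyond the scatter in both cases.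

The step now followed leads from compound 2 to compound 4 `CC(C)n1nc(-c2cc(-c3ccc(F)cc3)on2)c2c(N)ncnc21`, where the change is 4-fluorophenyl in place of ethyl on an aromatic carbon. Among the compounds with values here, no measured step touches this position: the only step on record, from compound 1 to compound 3, alters the group on the aromatic nitrogen, not the substituent on the five-membered ring, and it was within the scatter. The direction and size of the present step therefore cannot be read from the measured compounds, and only a wide expectation is possible.

Compound 4 is expected to give about 700 nM, somewhere between 150 nM and 3000 nM, which would mean an estimated step of a 2.2-fold lower number from compound 2 to compound 4 (0.35 log units; beyond the scatter).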

Compound 4, concentration for 50% growth inhibition: > 10000 nM
Compound 4: a limit, no number; the forecaster's own chance of this, stated with the estimate: 5%; at least 14-fold (1.15 log units) between middle value and limit.
By their numbers in this assay, from the lowest: compounds 3 and 1 (each within the scatter of the next); then compound 2. At a limit, above all of these: compound 4.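

In this assay compound 4 stands at a limit of the assay, not at a number: the limit of > 10000 nM in this assay, at which 1 of the 4 values shown sits. Going by these compounds alone, the substituent on the aromatic carbon next to the ring oxygen clearly matters, which no earlier compound could show: exchanging ethyl for 4-fluorophenyl at this place gives an at least 6.4-fold higher number from compound 2 to compound 4 (0.80 log units; beyond the scatter). Within the data shown here, the only earlier step, a 1.2-fold lower number from compound 1 to compound 3 (0.07 log units; within the scatter), changed the group on the aromatic nitrogen and left the number within the scatter, whereas this change on the five-membered ring, which brings in a six-membered aromatic ring of carbon carrying a fluorine, weakens growth inhibition well beyond it.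

The compounds shown do not separate the part played by the phenyl ring from that of its fluorine, for a plain phenyl does not appear among them, and they give no reason for the loss. They also leave open how a longer chain such as butyl, or a smaller group such as methyl, would behave at this place, and with that how large a group can sit here before growth inhibition fades.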